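Stretching the Chain on Compound 3: Ethyl to Hexyl

This account rests on a few compounds, and the source may have more. Where it says the series, first, only, none or still open, it means among the compounds named here.

Compound 1 `CCc1nncn1-c1ccc(OCc2cccc(F)c2)cc1` — 22.8 mg/kg
Compound 2 `CCc1nncn1-c1ccc(OCc2ccc(C)cc2)cc1` — 25.5 mg/kg
Compound 3 `CCOc1ccc(-n2cnnc2CC)cc1` — > 100 mg/kg

In a functional assay on the whole organism (strain C57B/6) with Mus musculus as the target, in the maximal electroshock model (a higher number here means that more compound is needed for the effect, a lower number that less compound is needed), compound 1 and compound 2 both give a number, and their step of a 1.1-fold higher number from compound 1 to compound 2 (0.05 log units; within the scatter) shows no difference to speak of. Compound 3 is different: in this assay it reports only a limit, (the limit of > 100 mg/kg in this assay, at which 1 of the 3 values shown sits), so its true value is not known, only that it sits beyond the range the test could reach.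

Compound 4 `CCCCCCOc1ccc(-n2cnnc2CC)cc1` is compound 3 with a longer chain: butyl in place of hydrogen on a saturated chain carbon, two bonds along the chain from an oxygen on an aromatic ring. Going by the values given here, two measured steps bear on this. an at least 4.3-fold higher number from compound 1 to compound 3 (0.64 log units; beyond the scatter) and an at least 3.9-fold higher number from compound 2 to compound 3 (0.59 log units; beyond the scatter) both show that cutting the aryl ring down to a bare methyl costs activity beyond the scatter. Compound 4 does not restore a ring; it only extends the chain, so the measured steps speak to its direction only weakly. Compound 3 already sits at the limit. From there the step can only be flat or toward a lower number.

The expected outcome for compound 4 is a modest drop, an at least 1.4-fold lower number from compound 3 to compound 4 (0.15 log units; that floor lies within the scatter), with compound 4 estimated at 70 mg/kg, ranging from 25 mg/kg to 200 mg/kg, and a fair chance that it, too, returns only a limit.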

Compound 4, dose for half-maximal effect: 13.2 mg/kg
Compound 4: the middle estimate sits 5.3-fold (0.72 log units) above what was measured; measured number below the stated range.
By their numbers in this assay, from the lowest: compounds 4, 1 and 2 (each within the scatter of the next). At a limit, above all of these: compound 3.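

Butyl in place of hydrogen on a saturated chain carbon, two bonds along the chain from an oxygen on an aromatic ring, gives an at least 7.5-fold lower number from compound 3 to compound 4 (0.87 log units; beyond the scatter) in this assay and so shows that activity can return with a plain chain and no second aromatic ring. The earlier compounds shown here showed activity only with an aryl group at this end, yet a 1.9-fold lower number from compound 2 to compound 4 (0.29 log units; within the scatter) and a 1.7-fold lower number from compound 1 to compound 4 (0.24 log units; within the scatter) leave the hexyl chain level with the 4-methylphenyl and 3-fluorophenyl groups, so in these compounds the ring is not needed for activity. The gain from compound 3 is a floor and not an exact size, because compound 3 gives only a limit: the limit of > 100 mg/kg in this assay, at which 1 of the 4 values shown sits.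

Where between the ethyl and hexyl chains the activity appears remains open, as does whether a longer chain such as octyl would keep it or lose it. Also open, from the compounds shown here alone, is what a hexyl chain ending in an amine or a carboxylic acid would do in the same test.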